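A 4-fluorophenyl in place of 2,3-dichlorophenyl

The compounds below may be only part of what the source reports. "The series", "measured", "known", "first", "only" and "open" are said of these compounds alone.

Compound 1 `COc1ccc(C(O)c2c(C)oc3c([C@H]4CCN(C)C[C@H]4O)c(O)cc(O)c3c2=O)cc1Br`: 41%
Compound 2 `Cc1oc2c([C@H]3CCN(C)C[C@H]3O)c(O)cc(O)c2c(=O)c1C(O)c1cccc(Cl)c1Cl`: 7%

In a functional assay on MCF7 cells (Homo sapiens) for inhibition, read by MTT assay, with a stated time of 48 h, tested at 10 uM (a lower number here means less inhibition of growth, a higher number more inhibition of growth at the concentration tested), compound 2 stands lowest of the two measured compounds, with compound 1 the nearest and only neighbour. The next compound to be tested, compound 3 `Cc1oc2c([C@H]3CCN(C)C[C@H]3O)c(O)cc(O)c2c(=O)c1C(O)c1ccc(F)cc1`, differs from compound 2 in one place (4-fluorophenyl in place of 2,3-dichlorophenyl on a saturated chain carbon bound to an aromatic carbon and an oxygen on a saturated carbon): 4-fluorophenyl in place of 2,3-dichlorophenyl on a saturated chain carbon bound to an aromatic carbon and an oxygen on a saturated carbon.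

Within the data shown here, one measured step bears on this change. It is a number 34 percentage points lower from compound 1 to compound 2 (beyond the scatter) and lies beyond the scatter. It was made at the same place, with 2,3-dichlorophenyl in place of 3-bromo-4-methoxyphenyl, so groups at this place have already given a large difference. Among the measured compounds shown here, that single step says little about 4-fluorophenyl, which no measured compound carries. Compound 2 at 7% has little room left to fall, so any clear move is more likely to be upward. An upward move smaller than the measured step is expected, namely a number 13 percentage points higher from compound 2 to compound 3 (beyond the scatter) in this assay with wide uncertainty. Compound 3 is therefore estimated at 20% (range 5% to 42%).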

Compound 3, percent growth inhibition at one concentration: 9%
Compound 3: the middle estimate sits 11 percentage points above what was measured; measured number inside the range.
By their numbers in this assay, from the lowest: compounds 2 and 3 (each within the scatter of the next); then compound 1.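

In this assay, 4-fluorophenyl in place of 2,3-dichlorophenyl on the saturated chain carbon gives a number 2 percentage points higher from compound 2 to compound 3 (within the scatter), so these two halogen-bearing phenyl groups cannot be told apart at this position, although one carries two chlorine atoms and the other a single fluorine. The new step of a number 32 percentage points lower from compound 1 to compound 3 (beyond the scatter) runs the same way as a number 34 percentage points lower from compound 1 to compound 2 (beyond the scatter), so the large difference at this place is no longer tied to the 2,3-dichlorophenyl group alone: it now separates 3-bromo-4-methoxyphenyl from both other groups. Nothing available explains why these groups read as they do.

The three compounds cannot show whether the bromine, the methoxy or the two together go with the higher number of compound 1, a question that 3-bromophenyl and 4-methoxyphenyl at the same place would address. They also leave open how this position responds to a phenyl group carrying something other than a halogen or methoxy, such as an amine or a carboxylic acid.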